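Swapping the Oxazole for a Cyanophenyl Group

A few compounds are considered here, and "the series" means these few. Any claim that something is new, unique, unknown or untested is made for them only; others in the source may bear on it.

Compound 1, `Nc1nc(-c2ccc(Cl)o2)nc2sc(CN3CC=CC3)cc12`: 780 nM
Compound 2, `Nc1nc(-c2ncco2)nc2sc(CN3CC=CC3)cc12`: 3890 nM
Compound 3, `Nc1nc(-c2ncco2)nc2sc(CN3CC=CCC3)cc12`: 2960 nM

Of the compounds shown here, three built on one shared core have been measured in an assay on CHO-K1 cells for antagonist activity at adenosine receptor A1 (Homo sapiens), read by a beta-galactosidase reporter, with stated times of 15 min and 6 h; a lower number here means a stronger inhibitor, a higher number a weaker inhibitor. Compound 2 gives the highest number of the three in this assay: compound 3 lies within the scatter of it, while compound 1 is clearly lower, as the step of a 5.0-fold higher number from compound 1 to compound 2 (0.70 log units; beyond the scatter) shows. The step of a 1.3-fold lower number from compound 2 to compound 3 (0.12 log units; within the scatter) indicates that the ring on the saturated chain carbon changes little here.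

Compound 4, `N#Cc1cccc(-c2nc(N)c3cc(CN4CC=CC4)sc3n2)c1`, is not yet measured. It differs from compound 2 in one place: 3-cyanophenyl in place of 1,3-oxazol-2-yl on an aromatic carbon. Within the data shown here, no measured step involves a 3-cyanophenyl group, so the only guide is the earlier exchange at this same position, a 5.0-fold higher number from compound 1 to compound 2 (0.70 log units; beyond the scatter), which was modest. Because an exchange at this position already produced a 5.0-fold higher number from compound 1 to compound 2 (0.70 log units; beyond the scatter), a step of similar size toward a lower number is expected. Compound 4 is therefore estimated to give 600 nM in this assay, within 120 nM to 3000 nM. The expected step is a 6.5-fold lower number from compound 2 to compound 4 (0.81 log units; beyond the scatter).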

Compound 4, inhibition constant: 2070 nM
Estimate against measurement, compound 4: 3.5-fold (0.54 log units) below; the measured number falls inside the stated range.
By their numbers in this assay, from the lowest: compound 1; then compounds 4, 3 and 2 (each within the scatter of the next).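

At this position of the shared core, the step to 3-cyanophenyl in this assay gives a 1.9-fold lower number from compound 2 to compound 4 (0.27 log units; within the scatter) and so leaves the number unmoved in any meaningful way, even though a carbon-only six-membered ring bearing a nitrile replaces a five-membered ring with two hetero atoms. The earlier compounds shown here showed one exchange here that mattered; this one shows that not every exchange at this position does. The 5-chlorofuran-2-yl group still stands apart, as replacing it gives a 2.7-fold higher number from compound 1 to compound 4 (0.42 log units; beyond the scatter) and compound 1 keeps the lowest number.

No measurement shown explains these differences. Open questions are whether a plain phenyl without the nitrile, or a furan-2-yl without the chlorine, would side with compound 4 or with compound 1, and whether the six-membered ring of compound 3 behaves alike alongside 3-cyanophenyl.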